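This account rests on a few compounds, and the source may have more. Where it says the series, first, only, none or still open, it means among the compounds named here.

Working notes on the series in a functional assay on the whole organism with Mus musculus as the target; on this read-out lower numbers stand for an effect already at smaller amounts and higher numbers for an effect only at larger amounts of compound. For the measured compounds named here, compound 1 (`CC(C)=Cc1c(C)c(N)c(C)c2c1OC(C)(C)C2`) gives 21.9 mg/kg, the only full number so far. Compound 2 (`Cc1c(C)c2c(c(C)c1N)CC(C)(CSCCO)O2`) reads > 50 mg/kg, and this is a limit of the assay. Compound 3 (`Cc1c(C)c2c(c(C)c1NC=O)CC(C)(C)O2`) reads > 100 mg/kg, which is again a limit. Compound 3 therefore has no number of its own, and its result is of the same kind as that of compound 2.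

Compound 4 (`CCOC(=O)Nc1c(C)c(C)c2c(c1C)CC(C)(C)O2`) keeps the shared core of compound 3 and turns formylamino into (ethoxycarbonyl)amino: ethoxy in place of hydrogen on a carbonyl carbon. The carbonyl carbon on the amide-type nitrogen stays in place.

Going by the values given here, no two measured compounds differ in one place only, so the series does not yet show the size of such a change in this assay. The expectation rests on compound 3, whose limit of > 100 mg/kg is the closest reading available. No step beyond the usual scatter is expected, in either direction. The estimated change is an at least 1.1-fold lower number from compound 3 to compound 4 (0.04 log units; that floor lies within the scatter), and the assay may well report only a limit again. Compound 4 is estimated at 90 mg/kg, with an expected range of 30 mg/kg to 250 mg/kg.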

Compound 4, dose for 50% inhibition: > 100 mg/kg
Compound 4: a limit, no number; the forecaster's own chance of this, stated with the estimate: 60%; at least 1.1-fold (0.04 log units) between middle value and limit.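

Compound 3 and compound 4 both read as limits rather than numbers, so no step between them can be read: the limit of > 100 mg/kg in this assay, at which 2 of the 4 values shown sit.

The compounds shown leave open whether ethoxy in place of hydrogen on a carbonyl carbon changes the effective dose at all and, if it does, in which direction and by how much.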